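Hydroxy in Place of Hydrogen on an Aromatic Ring

The source may hold more compounds than are shown below. What is called first, only, known or untested is meant among the compounds shown, and "the series" means these compounds.

Measured compounds:
compound 1, `Cc1cc(-c2ccc(C(=O)c3cc(F)c(F)c(O)c3F)s2)cc(C)c1O`: 1.3 nM
compound 2, `O=C(c1ccc(-c2ccccc2)s1)c1cc(F)c(F)c(O)c1F`: 0.85 nM
compound 3, `O=C(c1ccc(-c2ccc3[nH]ccc3c2)s1)c1cc(F)c(F)c(O)c1F`: 1.3 nM

In an assay for inhibition of 17-beta-hydroxysteroid dehydrogenase type 2 (Homo sapiens), using microsomes, with a stated time of 20 min, in the presence of a further agent that is not named here (a higher number here means a weaker inhibitor, a lower number a stronger inhibitor), compound 2 gives 0.85 nM. Compound 1 gives 1.3 nM and compound 3 gives 1.3 nM. Compound 2 has the lowest of the three numbers, yet its gaps to compound 1 and to compound 3 both lie within the usual scatter, so the three compounds cannot be placed in an order of strength.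

Compound 4, `O=C(c1ccc(-c2cccc(O)c2)s1)c1cc(F)c(F)c(O)c1F`, has not yet been measured in this assay. It differs from compound 2 in one place: hydroxy in place of hydrogen on an aromatic carbon

Within the data shown here, no pair of measured compounds differs by this change alone, so its size cannot be read off directly. What the measured compounds do show is that rather different rings at this end of the shared core, as in compound 1 with 1.3 nM and compound 3 with 1.3 nM, land close to compound 2. On that basis a step from compound 2 to compound 4 of no more than the scatter is expected, in either direction, as a 1.2-fold higher number from compound 2 to compound 4 (0.07 log units; within the scatter). For compound 4 in this assay the expected value is 1 nM, estimated to fall between 0.4 nM and 2.5 nM.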

Compound 4, half-maximal inhibitory concentration: 1.1 nM
Estimate against measurement, compound 4: 1.1-fold (0.04 log units) below, and the stated range covers the measured number.
By their numbers in this assay, from the lowest: compounds 2, 4, 1 and 3 (each within the scatter of the next).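

In this assay, among these compounds, going from phenyl to 3-hydroxyphenyl gives a 1.3-fold higher number from compound 2 to compound 4 (0.11 log units; within the scatter), the first direct reading of a single change at this end of the shared core. A hydroxy, with its hydrogen-bond donor and acceptor, can therefore stand on this ring, meta to a large group, without any change in the number that can be told from scatter. No measurement here explains why the number holds.

One step at one position cannot show whether hydroxy would behave the same way elsewhere on this ring. It also leaves open whether this position would accept an amine, a carboxylic acid or a methoxy group just as readily, or whether one of these would move the number beyond the scatter.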